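The source may hold more compounds than are shown below. What is called first, only, known or untested is meant among the compounds shown, and "the series" means these compounds.

Three compounds have been measured in an ADME assay on MT4 cells (Homo sapiens) for cytotoxicity, read by MTT assay, with a stated time of 4 days; on this read-out higher numbers stand for lower toxicity in this test and lower numbers for higher toxicity in this test:

Compound 1 `O=C(COc1cccc2ccccc12)N/N=C/c1ccccc1Br` gives 11.4 ug/mL.
Compound 2 `O=C(COc1cccc2ccccc12)N/N=C/c1cccc(O)c1` gives 32.6 ug/mL.
Compound 3 `O=C(COc1cccc2ccccc12)N/N=C/c1ccccc1Cl` gives 56.2 ug/mL.

Compound 3 has the highest number of the three. Its nearest neighbour is compound 2, and the gap a 1.7-fold higher number from compound 2 to compound 3 (0.24 log units; within the scatter) lies within the scatter, so the two cannot be told apart. Compound 1 lies furthest away, with a 4.9-fold higher number from compound 1 to compound 3 (0.69 log units; beyond the scatter) being beyond the scatter.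

Compound 4 `O=C(COc1cccc2ccccc12)N/N=C/c1ccc(F)cc1` has not yet been measured. It differs from compound 3 in one place: 4-fluorophenyl in place of 2-chlorophenyl on a carbon with a double bond to nitrogen.

Among the compounds with values here, no measured step mirrors this change exactly. The closest is the swap of one halogen for another at the same position, a 4.9-fold higher number from compound 1 to compound 3 (0.69 log units; beyond the scatter), a modest step. The replacement of the whole aryl group, a 2.9-fold higher number from compound 1 to compound 2 (0.46 log units; beyond the scatter), was also modest, while a 1.7-fold higher number from compound 2 to compound 3 (0.24 log units; within the scatter) stayed within the scatter. Halogen changes so far have moved the number by modest amounts in either direction, and there is no measured case of a halogen at this new position. The expected change for compound 4 is therefore small, a 1.6-fold lower number from compound 3 to compound 4 (0.21 log units; within the scatter), with no step beyond the scatter. Compound 4 is estimated to give 35 ug/mL, in a range from 12 ug/mL to 100 ug/mL.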

Compound 4, half-maximal cytotoxic concentration: 65.1 ug/mL
Compound 4: the middle estimate sits 1.9-fold (0.27 log units) below what was measured, within the range that was stated.
By their numbers in this assay, from the lowest: compound 1; then compounds 2, 3 and 4 (each within the scatter of the next).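

In this assay, replacing 2-chlorophenyl with 4-fluorophenyl on a carbon with a double bond to nitrogen changes both the halogen and its place on the ring, yet the two compounds cannot be told apart (a 1.2-fold higher number from compound 3 to compound 4 (0.06 log units; within the scatter)). The 3-hydroxyphenyl compound cannot be separated from the 4-fluorophenyl compound either (a 2.0-fold higher number from compound 2 to compound 4 (0.30 log units; within the scatter)), so at this place three differently substituted phenyl groups now give numbers within the usual scatter of one another, and a halogen is not needed to reach them. Only the 2-bromophenyl compound stands apart (a 5.7-fold higher number from compound 1 to compound 4 (0.76 log units; beyond the scatter)), which makes its higher toxicity in this test look specific to that group rather than typical of halogens here, as neither chloro nor fluoro shares it.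

Still open, on these data alone, is whether an amine or a carboxylic acid on the phenyl ring would stay with the three similar compounds or fall as low as compound 1. Nothing available here accounts for why compound 1 differs from the other three.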